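Swapping methoxy for fluoro on the arylpiperazine

The compounds below may be only part of what the source reports. "The series", "measured", "known", "first", "only" and "open" are said of these compounds alone.

Three compounds from one series of spiro-oxindole-like amides share a core; the study centres on their affinity in an assay on CHO cells for displacement of a labelled ligand from 5-hydroxytryptamine receptor 7 (Homo sapiens); a lower number here means a stronger inhibitor, a higher number a weaker inhibitor. Compound 1, `CCC1(CCCCN2CCN(c3ccc(OC)cc3)CC2)C(=O)Nc2ccccc21`, gives 25.4 nM in this assay. Compound 3, `CCC1(CCCN2CCN(c3cccc(Cl)c3)CC2)C(=O)Nc2ccccc21`, gives 21 nM in this assay, and its number and that of compound 1 lie within the usual scatter of one another, so neither stands apart. Compound 2, `CCC1(CCCCN2CCC(C)CC2)C(=O)Nc2ccccc21`, has the result "not determined" (no result reported) in this assay, and thus no number can be placed beside the other two.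

The step under consideration leads from compound 1 to compound 4, `CCC1(CCCCN2CCN(c3ccc(F)cc3)CC2)C(=O)Nc2ccccc21`. The change is fluoro in place of methoxy on an aromatic carbon, sitting para to a large group on the six-membered aromatic ring of carbon only. Among the compounds with values here, no measured pair in the set shows this same change, so the size of the step has to be estimated rather than read. Compound 4 is expected to stay near compound 1, with the expected step of a 1.4-fold higher number from compound 1 to compound 4 (0.14 log units; within the scatter) being a modest loss of affinity. For compound 4 the estimated inhibition constant is 35 nM, within a range from 12 nM to 100 nM.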

Compound 4, inhibition constant: 0.43 nM
Beside the measured number, compound 4's estimate is 81-fold (1.91 log units) above it; measured number outside the range, below it.
By their numbers in this assay, from the lowest: compound 4; then compounds 3 and 1 (each within the scatter of the next).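

In this assay, fluoro in place of methoxy on an aromatic carbon, para to a large group, gives a 59-fold lower number from compound 1 to compound 4 (1.77 log units; beyond the scatter). Within the data shown here, this position is therefore far from indifferent to the group it carries, something the earlier compounds could not show, as no pair among them differed here alone. Nothing measured in the data shown accounts for the size of this step.

On these data alone, it remains open whether the step reflects the arrival of fluoro or the departure of methoxy, and what chloro, methyl or plain hydrogen would give at the same place. Also open, as far as these compounds go, is whether the same exchange would produce a step of similar size with a shorter chain joining the piperazine to the shared core.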